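A few compounds are considered here, and "the series" means these few. Any claim that something is new, unique, unknown or untested is made for them only; others in the source may bear on it.

Going by the values given here, compound 2 `CC(C)c1n[nH]c2c(NCc3ccc(-c4ccccn4)cc3)nc(SC(C)C(C)O)nc12` gives 190 nM in a functional assay on HT cells (Homo sapiens) for antiproliferative activity, read by fluorescence, with a stated time of 72 h (on this read-out higher numbers stand for weaker inhibition of growth and lower numbers for stronger inhibition of growth), the lowest of the three numbers measured so far. Its nearest neighbour is compound 1 `CC(C)c1n[nH]c2c(NCc3ccc(-c4ccccn4)cc3)nc(SC(CO)C(C)C)nc12`, which gives 980 nM; the step of a 5.2-fold lower number from compound 1 to compound 2 (0.71 log units; beyond the scatter) lies beyond the scatter. Compound 3 `C=CCSc1nc(NCc2ccc(-c3ccccn3)cc2)c2[nH]nc(C(C)C)c2n1` gives 1010 nM, and the step of a 5.3-fold higher number from compound 2 to compound 3 (0.73 log units; beyond the scatter) is likewise beyond the scatter, whereas a 1.0-fold higher number from compound 1 to compound 3 (0.01 log units; within the scatter) is within it.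

Compound 4 `CCC(CO)Sc1nc(NCc2ccc(-c3ccccn3)cc2)c2[nH]nc(C(C)C)c2n1` differs from compound 2 only at the sulfur: 1-(hydroxymethyl)propyl in place of 2-hydroxy-1-methylpropyl on a sulfur. Both steps away from the 2-hydroxy-1-methylpropyl group of compound 2 raised the number by a modest amount, and compound 4 carries a 1-(hydroxymethyl)propyl group, whose name shares the 1-(hydroxymethyl) pattern of the 1-(hydroxymethyl)-2-methylpropyl group of compound 1. On that basis a modest rise in this assay is expected for compound 4, roughly a 3.4-fold higher number from compound 2 to compound 4 (0.53 log units; beyond the scatter), though a smaller change cannot be excluded from three compounds. The estimate for compound 4 is 650 nM, with a range from 250 nM to 1800 nM.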

Compound 4, concentration for 50% growth inhibition: 255 nM
Compound 4: the middle estimate sits 2.5-fold (0.41 log units) above what was measured; measured number inside the range.
By their numbers in this assay, from the lowest: compounds 2 and 4 (each within the scatter of the next); then compounds 1 and 3 (each within the scatter of the next).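

The two side chains with the same atoms joined differently are not told apart in this assay (a 1.3-fold higher number from compound 2 to compound 4 (0.13 log units; within the scatter)), so this rearrangement on the sulfur does not register here. The higher number of compound 1 does not follow from the 1-(hydroxymethyl) pattern alone, since replacing one methyl with hydrogen gives a 3.8-fold lower number from compound 1 to compound 4 (0.58 log units; beyond the scatter) and the chain of compound 4 stands clear of that of compound 1. Compound 4 also stands clear of the allyl chain (a 4.0-fold lower number from compound 3 to compound 4 (0.60 log units; beyond the scatter)), as compound 2 does, but compound 1 goes against any reading that a hydroxyl-bearing chain is enough on its own.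

Nothing at hand explains these steps. Still open, as far as these compounds go, is how this position responds when an amine or a carboxylic acid replaces the hydroxyl, or when a longer saturated chain sits on the sulfur.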